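Metabolic stability notes: the step from compound 3 to compound 4

The source may report more compounds than this note shows. Statements on the series, on what has been measured and on what is new or still open speak of the compounds shown alone.

Measured so far:
- compound 1, `CC(=O)N[C@@H]1CCN(c2cc(C)nn3c(-c4cccc(S(=O)(=O)N(C)C)c4)c(C)nc23)C1`: in an ADME assay on microsomes from liver (Homo sapiens) for metabolic stability, read by LC-MS, with NADPH named in the record, with a stated time of 60 min, tested at 1 uM, in the absence of a further agent (a higher number here means that more of the compound is left, a lower number that less of the compound is left), compound 1 gives > 95%, a limit of the assay
- compound 2, `CC(=O)N[C@@H]1CCN(c2cc(C)nn3c(-c4nccs4)c(C)nc23)C1`: in this assay compound 2 gives > 95%, a limit of the assay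
- compound 3, `COc1ccc(-c2c(C)nc3c(N4CC[C@@H](NC(=O)Nc5ccccc5)C4)cc(C)nn23)cc1OC`: in this assay compound 3 gives > 95%, a limit of the assay

Compound 3 stands at the upper limit of this assay, not at a number, and the other two compounds in the series give the same limit (the limit of > 95% in this assay, at which 3 of the 3 values shown sit). Among the measured compounds shown here, with three values all at the limit, no ordering among them can be read, and no step between compounds that differ in one place has been measured.

Compound 4, `COc1ccc(-c2c(C)nc3c(N4CC[C@@H](NS(=O)(=O)c5cccs5)C4)cc(C)nn23)cc1OC`, is compound 3 with (thiophen-2-yl)sulfonyl in place of phenylcarbamoyl on an amine nitrogen whose other neighbours are a saturated ring carbon ((thiophen-2-yl)sulfonyl in place of phenylcarbamoyl on an amine nitrogen).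

For the measured compounds named here, no measured step informs the change, so the expectation for this assay rests on compound 3 sitting at the limit: the step of a number at least 5 percentage points lower from compound 3 to compound 4 (that floor lies within the scatter) is expected to be small and, if anything, downward, within the usual scatter. Compound 4 is expected to give about 90%, in the range 75% to 97%, with a fair chance that only the limit is reported again.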

Compound 4, percent of the compound remaining: > 95%
Compound 4: only a limit was reported (the forecaster's own chance of this, stated with the estimate: 55%); at least 5 percentage points between middle value and limit.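

Compound 3 and compound 4 both stand at a limit of this assay, so no step between them can be read: the limit of > 95% in this assay, at which 4 of the 4 values shown sit.

The compounds shown leave open whether (thiophen-2-yl)sulfonyl in place of phenylcarbamoyl changes the percent of compound remaining at all, and which compound in the series would give a value away from the limit.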